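A few compounds are considered here, and "the series" means these few. Any claim that something is new, unique, unknown or untested is made for them only; others in the source may bear on it.

Compound 1 `CC(C)(C)OC(=O)N1CCC[C@H]1C(=O)O[C@@H]1CO[C@H]2[C@@H]1OC[C@H]2OCc1ccccc1` and compound 2 `CC(C)[C@@H](NC(=O)OC(C)(C)C)C(=O)O[C@@H]1CO[C@H]2[C@@H]1OC[C@H]2OCc1ccccc1` share one core and differ only in the ester-linked amino acid. In an assay for inhibition of kallikrein-5 (Homo sapiens), read by FRET, with a stated time of 5 min (a higher number here means a weaker inhibitor, a lower number a stronger inhibitor), compound 1 gives 521000 nM, while compound 2 gives 223000 nM, the lower of the two numbers, a gap that lies beyond the scatter. Compound 3 `CC(C)(C)OC(=O)N[C@H](COCc1ccccc1)C(=O)O[C@@H]1CO[C@H]2[C@@H]1OC[C@H]2OCc1ccccc1` is not yet measured; it differs from compound 2 by (benzyloxy)methyl in place of isopropyl on a saturated chain carbon bound to an amide-type nitrogen and a carbonyl carbon. Within the data shown here, no measured pair shows this change, so the step is expected to be modest and downward in this assay, as a 1.5-fold lower number from compound 2 to compound 3 (0.17 log units; within the scatter). Compound 3 is therefore estimated at 150000 nM, within a range from 40000 nM to 500000 nM.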

Compound 3, half-maximal inhibitory concentration: 15500 nM
For compound 3 the middle estimate is 9.7-fold (0.99 log units) above the measured one; the whole stated range lies above it.
By their numbers in this assay, from the lowest: compound 3; then compound 2; then compound 1.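

Within this assay this position, a saturated chain carbon bound to an amide-type nitrogen and a carbonyl carbon, turns out to be highly sensitive to what it carries: (benzyloxy)methyl in place of isopropyl gives a 14-fold lower number from compound 2 to compound 3 (1.16 log units; beyond the scatter) and makes compound 3 the lowest of the three numbers. No measurement shown accounts for this step. The change brings in both an ether oxygen and an aromatic ring, and these compounds do not separate the two. From the compounds shown here alone, whether a plain benzyl, a hydroxymethyl or an aminomethyl group would give a similar number remains open.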